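Lengthening the hydroxamic acid chain on the shared core

The source may report more compounds than this note shows. Statements on the series, on what has been measured and on what is new or still open speak of the compounds shown alone.

Measured so far:
compound 1, `Nc1nc2cc(-c3nn(CCCC(=O)NO)c4ncnc(N)c34)ccc2o1`: 19500 nM
compound 2, `Nc1ncnc2c1c(-c1cnc3[nH]ccc3c1)nn2CCCCC(=O)NO`: > 50000 nM

Going by the values given here, in a functional assay on MDA-MB-231 cells (Homo sapiens) for inhibition, read by MTT assay, with a stated time of 72 h (on this read-out higher numbers stand for weaker inhibition and lower numbers for stronger inhibition), compound 1 gives 19500 nM, and this is the only value that stands as a number. Compound 2 gives > 50000 nM in this assay, which is a limit of the assay and not a number. The remaining value thus sits at the limit of > 50000 nM in this assay, at which 1 of the 2 values shown sits, so compound 1 is the only anchor for any expectation.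

Compound 3, `Nc1nc2cc(-c3nn(CCCCCCC(=O)NO)c4ncnc(N)c34)ccc2o1`, has not yet been measured in this assay. It differs from compound 1 as follows: 3-(hydroxycarbamoyl)propyl in place of hydroxycarbamoyl on a saturated chain carbon, three bonds along the chain from an aromatic nitrogen. Among the compounds with values here, no pair of measured compounds shows what such a chain lengthening does on this core; compound 2 carries a different core as well as a different chain, so its limit offers no comparison.

The step in this assay is expected to be a moderate gain in inhibition, estimated as a 2.4-fold lower number from compound 1 to compound 3 (0.39 log units; beyond the scatter). Compound 3 is therefore estimated to give 8000 nM in this assay, with a likely range from 2000 nM to 30000 nM.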

Compound 3, half-maximal inhibitory concentration: 8430 nM
Compound 3: the middle estimate sits 1.1-fold (0.02 log units) below what was measured; low and high end bracket the measured number.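

Going by these compounds alone, this is the first direct reading of what chain length does on the shared core: in this assay, placing 3-(hydroxycarbamoyl)propyl in place of hydroxycarbamoyl, on a saturated chain carbon, three bonds along the chain from an aromatic nitrogen, gives a 2.3-fold lower number from compound 1 to compound 3 (0.36 log units; beyond the scatter). The position therefore accepts a longer chain with the hydroxamic acid still at its end, and on this pair the longer chain goes with a modest gain in inhibition that lies beyond the usual scatter. This is a single step between two compounds, so it gives a direction and not a trend, and nothing measured here accounts for it.

As far as these compounds go, it remains open whether inhibition would keep improving with a still longer chain, how the intermediate chain lengths would compare, and whether a carboxylic acid could stand in place of the hydroxamic acid at the chain end. Compound 2 cannot settle the question of chain length, since its value is a limit and it differs from the others in its core as well as its chain.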